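Enlarging the Ring Substituent on a Shared Nucleoside Core

The source may report more compounds than this note shows. Statements on the series, on what has been measured and on what is new or still open speak of the compounds shown alone.

Compound 3 `Nc1nc(N)c2c(-c3ccoc3)cn([C@@H]3O[C@H](CO)[C@@H](O)[C@H]3O)c2n1` was tested in a functional assay on CCRF-CEM cells (Homo sapiens), read by MTT assay, with a stated time of 72 h; on this read-out higher numbers stand for weaker inhibition and lower numbers for stronger inhibition. In this assay compound 3 gives > 20000 nM, which is a limit of the assay rather than a measured number. Compound 1 `Nc1nc(N)c2c(-c3ccccc3)cn([C@@H]3O[C@H](CO)[C@@H](O)[C@H]3O)c2n1` gives > 20000 nM in this assay, again a limit. Compound 2 `Cc1nc(N)c2c(-c3cc4ccccc4o3)cn([C@@H]3O[C@H](CO)[C@@H](O)[C@H]3O)c2n1` likewise gives > 20000 nM, also a limit. The step that the two limits leave unreadable from compound 1 to compound 3 therefore has no readable size, because of the limit of > 20000 nM in this assay, at which 3 of the 3 values shown sit. Compound 4 `Nc1nc(N)c2c(-c3cc4ccccc4o3)cn([C@@H]3O[C@H](CO)[C@@H](O)[C@H]3O)c2n1` differs from compound 3 in one place: 1-benzofuran-2-yl in place of furan-3-yl on an aromatic carbon. Among the measured compounds shown here, no measured step shows what this change does to inhibition, as every value shown so far is a limit. Compound 4 is nonetheless expected to stay weak, with an estimated step that the limit leaves unreadable from compound 3 to compound 4 and an estimated value of 30000 nM, in the range 10000 nM to 100000 nM.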

Compound 4, half-maximal inhibitory concentration: > 20000 nM
Compound 4: a limit, no number; the forecaster's own chance of this, stated with the estimate: 80%; the middle value is on the limit's open side.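

The steps from compound 1, compound 2 and compound 3 to compound 4 cannot be read: the limit of > 20000 nM in this assay, at which 4 of the 4 values shown sit. The compounds shown leave open, in this assay, how strongly any of these four compounds actually inhibits and whether their groups differ at all.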